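This account rests on a few compounds, and the source may have more. Where it says the series, first, only, none or still open, it means among the compounds named here.

Measured so far:
compound 1, `COc1ccc(NS(=O)(=O)c2ccc(N3CCNC3=O)cc2)cc1` — > 1000 nM
compound 2, `O=C1NCCN1c1ccc(S(=O)(=O)Nc2ccc(OC(F)F)cc2)cc1` — 760 nM
compound 3, `CC(C)Cc1ccc(NS(=O)(=O)c2ccc(N3CCNC3=O)cc2)cc1` — > 1000 nM

In a functional assay on MCF7 cells (Homo sapiens) for antiproliferative activity, read by sulforhodamine B assay, with a stated time of 48 h (on this read-out lower numbers stand for stronger inhibition and higher numbers for weaker inhibition), compound 1 gives only a limit of the assay, > 1000 nM. Compound 3 likewise reaches only a limit, > 1000 nM. Compound 2 alone gives a number, 760 nM. Across the set, (the limit of > 1000 nM in this assay, at which 2 of the 3 values shown sit), so compound 1 cannot be placed more closely than at that limit. The step of an at least 1.3-fold lower number from compound 1 to compound 2 (0.11 log units; that floor lies within the scatter) and the step of an at least 1.3-fold higher number from compound 2 to compound 3 (0.11 log units; that floor lies within the scatter) are each readable only as a floor, and the step that the two limits leave unreadable from compound 1 to compound 3 is not readable at all.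

Compound 4, `COc1cccc(NS(=O)(=O)c2ccc(N3CCNC3=O)cc2)c1`, is not yet measured. It differs from compound 1 by 3-methoxyphenyl in place of 4-methoxyphenyl on a sulfonamide nitrogen. Among the compounds with values here, each of the three measured steps exchanges one group for another on the same carbon of the shared core; none of them moves a group from one carbon to another while keeping it intact, so no measured step bears directly on this change. Within the data shown here, the only anchor is that compound 1 stands at a limit, and a change of this kind gives no reason to expect a shift beyond the scatter.

The step that the limit leaves unreadable from compound 1 to compound 4 is therefore expected to lie within the scatter. Compound 4 is estimated at 1500 nM, with a range from 500 nM to 5000 nM, and a further limit rather than a number is the more likely outcome.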

Compound 4, half-maximal inhibitory concentration: 120 nM
Estimate against measurement, compound 4: 13-fold (1.10 log units) above; measured number below the stated range.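

In this assay, 3-methoxyphenyl in place of 4-methoxyphenyl on a sulfonamide nitrogen gives an at least 8.3-fold lower number from compound 1 to compound 4 (0.92 log units; beyond the scatter). Within the data shown here, the earlier steps exchanged one group for another and, where they could be read at all, gave only floors within the scatter; this is the first step read as beyond the scatter, and it comes from the same atoms joined differently, so the placing of the methoxy group matters here and not only the group's identity. The size of the step remains a floor, and the true difference may be larger, because compound 1 stands at a limit of the assay: the limit of > 1000 nM in this assay, at which 2 of the 4 values shown sit.

From the compounds shown here alone, it remains open whether the lower number belongs to methoxy itself or to the place it occupies in 3-methoxyphenyl; an ethoxy group, a chlorine atom or an amine in that same place would separate the two. It is also open whether difluoromethoxy and isobutyl, shown here only in compound 2 and compound 3, would respond to the same move as methoxy does.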